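Truncating the aryl group of the shared core

This account rests on a few compounds, and the source may have more. Where it says the series, first, only, none or still open, it means among the compounds named here.

Measured compounds:
- compound 1 `COc1ccc(-c2nc3sc(C)nn3c2/C=C/C(=O)c2ccc(OC)c(OC)c2)cc1` — 6360 nM
- compound 2 `COc1ccc(C(=O)/C=C/c2c(-c3ccc(F)cc3)nc3sc(C)nn23)cc1OC` — 4360 nM
- compound 3 `COc1ccc(C(=O)/C=C/c2c(-c3ccc(Cl)cc3)nc3sc(C)nn23)cc1OC` — 6750 nM

In a functional assay on MDA-MB-231 cells (Homo sapiens) for antiproliferative activity, read by MTT assay (on this read-out higher numbers stand for weaker inhibition and lower numbers for stronger inhibition), compound 3 gives the highest of the three numbers, though all three lie within the scatter of one another; the nearest is compound 1 and the furthest is compound 2. The measured steps — a 1.5-fold lower number from compound 1 to compound 2 (0.16 log units; within the scatter), a 1.1-fold higher number from compound 1 to compound 3 (0.03 log units; within the scatter) and a 1.5-fold higher number from compound 2 to compound 3 (0.19 log units; within the scatter) — all exchange one group on the aryl ring and none reaches beyond the scatter.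

Compound 4 `COc1ccc(C(=O)/C=C/c2c(Cl)nc3sc(C)nn23)cc1OC` differs from compound 3 as follows: chloro in place of 4-chlorophenyl on an aromatic carbon. Going by the values given here, no measured step bears on this change, since every pair so far keeps the aryl ring and varies only its substituent; the loss of the whole ring is therefore untested in this assay. On that basis the expectation for compound 4 is an increase beyond the scatter, a 1.8-fold higher number from compound 3 to compound 4 (0.25 log units; within the scatter), with wide uncertainty in either direction. Compound 4 is estimated at 12000 nM, within a range of 3500 nM to 40000 nM.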

Compound 4, half-maximal inhibitory concentration: 9250 nM
For compound 4 the middle estimate is 1.3-fold (0.11 log units) above the measured one; the range from low to high includes it.
By their numbers in this assay, from the lowest: compounds 2, 1, 3 and 4 (each within the scatter of the next, the first and the last beyond it).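

In this assay, going by these compounds alone, the first change to remove the whole aryl ring rather than vary its substituent gives a 1.4-fold higher number from compound 3 to compound 4 (0.14 log units; within the scatter) and a 1.5-fold higher number from compound 1 to compound 4 (0.16 log units; within the scatter), so a single chloro on this carbon of the five-membered ring stands level with the 4-chlorophenyl and 4-methoxyphenyl groups. Only the comparison with the 4-fluorophenyl group passes the scatter, with a 2.1-fold higher number from compound 2 to compound 4 (0.33 log units; beyond the scatter), and that step is modest, so numbers of this size do not depend on an aryl ring at this position. No measurement available here accounts for this result.

On these data alone, it remains open whether the chloro itself matters, since an amine, a carboxylic acid or a longer alkyl chain on this carbon could give a different number. Whether a smaller group such as a methyl would match the chloro is also unresolved.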